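This account rests on a few compounds, and the source may have more. Where it says the series, first, only, none or still open, it means among the compounds named here.

Compounds measured:
Compound 1 `Cc1[nH]n(C(C)(C)C)c(=O)c1/N=N/c1c(O)cc(S(=O)(=O)O)c2ccccc12`; in an assay on BaF3 cells with thrombopoietin receptor (Homo sapiens) as the target, read by a luciferase reporter (on this read-out lower numbers stand for smaller maximal responses and higher numbers for larger maximal responses), compound 1 returns only the assay limit < 5%.
Compound 2 `Cc1[nH]n(-c2ccc(C(C)(C)C)cc2)c(=O)c1/N=N/c1c(O)cc(S(=O)(=O)O)c2ccccc12`; compound 2 gives 86%.

Among the measured compounds shown here, compound 2 holds the only number in this assay; the other value is a limit (the limit of < 5% in this assay, at which 1 of the 2 values shown sits). For the measured compounds named here, the single measured step, a number at least 81 percentage points higher from compound 1 to compound 2 (beyond the scatter), is large. Compound 3 `Cc1[nH]n(-c2ccc(C(=O)O)cc2)c(=O)c1/N=N/c1c(O)cc(S(=O)(=O)O)c2ccccc12` differs from compound 2 by carboxy in place of tert-butyl on an aromatic carbon. That measured step concerned the group on the aromatic nitrogen, not a substituent on the phenyl, so it bears on the present step only loosely. Compound 3 is expected to keep much of the response, with an estimated step of a number 31 percentage points lower from compound 2 to compound 3 (beyond the scatter), giving an estimate of 55% within 15% to 90%.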

Compound 3, largest response reached (reported as efficacy), in percent of the reference or control that the assay uses: < 5%
Compound 3 ended at the assay's limit; the forecaster's own chance of this, stated with the estimate: 15%; middle value at least 50 percentage points from the limit.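

Keeping the phenyl on the aromatic nitrogen does not by itself hold the response in this assay: carboxy in place of tert-butyl on an aromatic carbon gives a number at least 81 percentage points lower from compound 2 to compound 3 (beyond the scatter). The gain seen earlier, a number at least 81 percentage points higher from compound 1 to compound 2 (beyond the scatter), therefore depends on what the phenyl carries and not on the ring alone. The value of compound 3 is a limit, and the step between compound 1 and compound 3 cannot be read, as both values are limits.

From the compounds shown here alone, whether a methyl ester, an amine or a shorter alkyl group such as methyl at this place keeps any response stays open. Going by these compounds, how far the response falls between tert-butyl and carboxy also stays open.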